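Nitro to Trifluoromethyl, Repeated on a Second Core

A few compounds are considered here, and "the series" means these few. Any claim that something is new, unique, unknown or untested is made for them only; others in the source may bear on it.

Three compounds have been measured in an assay on isolated protein for binding affinity to stress-70 protein, mitochondrial (Homo sapiens); a higher number here means weaker binding, a lower number tighter binding:
compound 1, `CC1(C)CCNc2ccc(NC(=S)Nc3ccc([N+](=O)[O-])cc3)cc21`, gives 1600 nM;
compound 2, `CC1(C)CCNc2ccc(NC(=S)Nc3ccc(C(F)(F)F)cc3)cc21`, gives 3300 nM;
compound 3, `CN1c2ccc(NC(=S)Nc3ccc([N+](=O)[O-])cc3)cc2C(C)(C)C(O)C1(C)C`, gives 2300 nM.

Compound 1 and compound 2 share one core and differ in a single place: trifluoromethyl in place of nitro on an aromatic carbon. That change gave a 2.1-fold higher number from compound 1 to compound 2 (0.31 log units; beyond the scatter) in this assay.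

Compound 3 stands on a different core. How the two cores differ is not broken down here. Compound 4, `CN1c2ccc(NC(=S)Nc3ccc(C(F)(F)F)cc3)cc2C(C)(C)C(O)C1(C)C`, is not yet measured; it differs from compound 3 by the same change, (trifluoromethyl in place of nitro on an aromatic carbon), at the same kind of place as in the first pair.

The expectation for compound 4 rests on the measured step, a 2.1-fold higher number from compound 1 to compound 2 (0.31 log units; beyond the scatter), and on compound 3 at 2300 nM. In this assay compound 4 is expected to show a 2.1-fold higher number from compound 3 to compound 4 (0.32 log units; beyond the scatter), a weakening of about the earlier size. The estimated value for compound 4 in this assay is 4800 nM, with a likely range from 2500 nM to 9500 nM.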

Compound 4, dissociation constant: 2300 nM
For compound 4 the middle estimate is 2.1-fold (0.32 log units) above the measured one; measured number below the stated range.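

On the second core, trifluoromethyl in place of nitro gave no change at the digits printed from compound 3 to compound 4 (within the scatter) in this assay. Set side by side, the two steps cannot be told apart, so these results give no firm sign that the core alters what this change does: the same change on two cores in this assay, a 2.1-fold higher number (0.31 log units; beyond the scatter) from compound 1 to compound 2 and no change at the digits printed (within the scatter) from compound 3 to compound 4, 2.1-fold (0.31 log units) apart, within the scatter of two such steps

This does not prove that the change carries over at a fixed size, since two pairs cannot separate one small shared step from a real weakening on the first core and none on the second.

The compounds shown carry only nitro and trifluoromethyl at this place on the aromatic ring, so it remains open what a nitrile, an amine or a carboxylic acid would do there on either core. As far as these compounds go, it is also open whether the same change on a third core would give a step like either of these two, and repeat measurements of both pairs would show how firm the comparison is.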